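The source may hold more compounds than are shown below. What is called first, only, known or untested is meant among the compounds shown, and "the series" means these compounds.

Measured so far:
Compound 1 `CCOC(=O)C(=O)Nc1ccc(N(C)C)cc1C#N`: 1 mg/kg
Compound 2 `CCOC(=O)C(=O)Nc1cc(N(C)C)ccc1C#N`: 1.9 mg/kg
Compound 3 `CCOC(=O)C(=O)Nc1cccc(N(CC)CC)c1C#N`: 0.7 mg/kg

In a functional assay on the whole organism with Rattus norvegicus as the target (a higher number here means that more compound is needed for the effect, a lower number that less compound is needed), compound 3 gives 0.7 mg/kg. This lies within the scatter of compound 1 at 1 mg/kg, while compound 2 at 1.9 mg/kg shows a higher number, beyond the scatter.

Compound 4 `CCOC(=O)C(=O)Nc1cccc(F)c1C#N` carries fluoro in place of diethylamino on an aromatic carbon. Among the measured compounds shown here, no measured compound lacks an amino group, and no measured pair differs in one place, so the data give no direct guide. A moderate rise is expected, with a wide margin, and the estimated step is a 2.9-fold higher number from compound 3 to compound 4 (0.46 log units; beyond the scatter). For compound 4 the estimated value is 2 mg/kg, with an expected range from 0.6 mg/kg to 7 mg/kg.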

Compound 4, dose for half-maximal effect: 1.2 mg/kg
Compound 4: the middle estimate sits 1.7-fold (0.22 log units) above what was measured, and the stated range covers the measured number.
By their numbers in this assay, from the lowest: compounds 3, 1, 4 and 2 (each within the scatter of the next, the first and the last beyond it).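

Fluoro in place of diethylamino on this aromatic carbon, ortho to a cyano group, gives a 1.7-fold higher number from compound 3 to compound 4 (0.23 log units; within the scatter) in this assay. Among the compounds shown here, this is the first direct comparison at this position, and it shows that the diethylamino group can leave without a shift beyond the scatter, so an amino group is not needed here for a number of this size. No measurement shown accounts for this result.

On these data alone, whether a morpholine, a methoxy group or a carboxylic acid at this position would fit the same range remains open. So does the outcome of placing fluoro where compound 1 carries dimethylamino.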